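Adding 2-cyclohexylethyl to compound 3 at the assay limit

The compounds below may be only part of what the source reports. "The series", "measured", "known", "first", "only" and "open" are said of these compounds alone.

Measured in a functional assay on SK-BR-3 cells (Homo sapiens) for antiproliferative activity, read by MTT assay, with a stated time of 72 h (on this read-out higher numbers stand for weaker inhibition and lower numbers for stronger inhibition), so far:
- compound 1 (`C=C(C)CCOC(=O)C[C@@H]1C(C(=O)OC)=CO[C@@H](O[C@@H]2O[C@H](COC(C)=O)[C@@H](OC(C)=O)[C@H](OC(C)=O)[C@H]2OC(C)=O)/C1=C/C`) gives > 15000 nM as a limit
- compound 2 (`C#CCOC(=O)C[C@@H]1C(C(=O)OC)=CO[C@@H](O[C@@H]2O[C@H](COC(C)=O)[C@@H](OC(C)=O)[C@H](OC(C)=O)[C@H]2OC(C)=O)/C1=C/C`) gives > 15000 nM as a limit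
- compound 3 (`C/C=C1/[C@H](O[C@@H]2O[C@H](COC(C)=O)[C@@H](OC(C)=O)[C@H](OC(C)=O)[C@H]2OC(C)=O)OC=C(C(=O)OC)[C@H]1CC(=O)O`) gives > 15000 nM as a limit

Compound 3 therefore has no exact number, and > 15000 nM marks a limit of the assay. The same holds for compound 1 and compound 2, so no order among the three can be read.

The next structure is compound 4 (`C/C=C1/[C@H](O[C@@H]2O[C@H](COC(C)=O)[C@@H](OC(C)=O)[C@H](OC(C)=O)[C@H]2OC(C)=O)OC=C(C(=O)OC)[C@H]1CC(=O)OCCC1CCCCC1`), and the difference from compound 3 is this: 2-cyclohexylethyl in place of hydrogen on an oxygen next to a carbonyl group and the rest of the structure stays the same.

Among the measured compounds shown here, two measured steps bear on this change, each with hydrogen entering on that same oxygen. One is a step that the two limits leave unreadable from compound 1 to compound 3 and the other is a step that the two limits leave unreadable from compound 2 to compound 3 so neither gives a size to carry over. The firm point is the limit of > 15000 nM in this assay, at which 3 of the 3 values shown sit, and it covers compound 1 and compound 2, which already carry other groups on that oxygen.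

Compound 4 is therefore expected to stay weak in this assay and will probably also report only a limit. The estimated step is a step that the limit leaves unreadable from compound 3 to compound 4 and no clear change is expected from it. Compound 4 is estimated at 20000 nM with an expected range from 8000 nM to 50000 nM in this estimate.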

Compound 4, half-maximal inhibitory concentration: > 15000 nM
Compound 4: no number, only a limit; the forecaster's own chance of this, stated with the estimate: 70%; the middle value lies beyond the limit too.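

In this assay compound 4 gives > 15000 nM, which is a limit and not a number. The steps to compound 4 from compound 1, compound 2 and compound 3 therefore cannot be read: the limit of > 15000 nM in this assay, at which 4 of the 4 values shown sit. The compounds shown leave open whether any group on the oxygen next to a carbonyl group can give an exact value in this assay.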